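Notes on a spiro series tested on liver cancer cells

A few compounds are considered here, and "the series" means these few. Any claim that something is new, unique, unknown or untested is made for them only; others in the source may bear on it.

Compound 1 `N#CC1=C(N)Oc2c(c3nc4ccccc4nc3c3ccccc23)C12C(=O)N(Cc1cnnn1-c1ccc(Cl)cc1)c1ccccc12` and compound 2 `N#CC1=C(N)Oc2c(c3nc4ccccc4nc3c3ccccc23)C12C(=O)N(Cc1cnnn1-c1ccc([N+](=O)[O-])cc1)c1ccccc12` share one core and differ in a single place, chloro in place of nitro on an aromatic carbon. In a functional assay on HepG2 cells (Homo sapiens) for antiproliferative activity, read by MTT assay, with a stated time of 48 h (a higher number here means a weaker inhibitor, a lower number a stronger inhibitor), compound 2 reaches only a limit of the measurement, > 50000 nM. Compound 1 likewise sits at a limit in this assay, > 50000 nM. The step that the two limits leave unreadable from compound 2 to compound 1 cannot be sized because the limit of > 50000 nM in this assay, at which 2 of the 3 values shown sit, holds both of its ends.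

Compound 3 `N#CC1=C(N)Oc2c(N)cc3nc4ccccc4nc3c2C12C(=O)N(Cc1cnnn1-c1ccc([N+](=O)[O-])cc1[N+](=O)[O-])c1ccccc12` is built on a different core; the difference between the two cores is not broken down here. In this assay, for the measured compounds named here, compound 3 gives 18400 nM, the only number in the set.

Compound 4 `N#CC1=C(N)Oc2c(N)cc3nc4ccccc4nc3c2C12C(=O)N(Cc1cnnn1-c1ccc(Cl)cc1[N+](=O)[O-])c1ccccc12` remains to be measured. It differs from compound 3 by chloro in place of nitro on an aromatic carbon. This is the same kind of change as from compound 2 to compound 1, not the same one: in compound 3 the place is meta to a nitro group, a neighbour that compound 2 lacks, so the change reads 2,4-dinitrophenyl to 4-chloro-2-nitrophenyl rather than 4-nitrophenyl to 4-chlorophenyl.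

The expected step of a 1.1-fold higher number from compound 3 to compound 4 (0.04 log units; within the scatter) is small. That expectation rests on the step that the two limits leave unreadable from compound 2 to compound 1, which cannot be sized. It rests also on compound 3 giving 18400 nM as the only anchor. Compound 4 is therefore estimated at 20000 nM in this assay, most likely between 7000 nM and 60000 nM.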

Compound 4, half-maximal inhibitory concentration: > 50000 nM
Compound 4: only a limit was reported; the forecaster's own chance of this, stated with the estimate: 35%; at least 2.5-fold (0.39 log units) between middle value and limit.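

In this assay, chloro in place of nitro reads as an at least 2.7-fold higher number from compound 3 to compound 4 (0.43 log units; beyond the scatter), and this size is only a floor, with the upper end of the step left unbounded. The same kind of change on the core of compound 1 cannot be read, and the data therefore do not show whether the step carries over from one core to the other, because compound 1 and compound 2 both sit at a limit of the measurement: the limit of > 50000 nM in this assay, at which 3 of the 4 values shown sit. The two changes are also not identical, since in compound 3 the place is meta to a nitro group that compound 2 lacks, so the loss seen here cannot be assigned to the core or to that second nitro group alone.

For the compounds shown here, with compound 3 the only compound giving a number, the series offers a single measured anchor, and how much room lies beyond the limit stays open. Also open, on these data alone, is whether another group at this place, such as an amine or a carboxylic acid, would give a number on either core, and how a 2,4-dinitrophenyl group would read on the core of compound 1.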